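Carbamate to carbonate step at the carbonyl carbon of the side chain

The source may report more compounds than this note shows. Statements on the series, on what has been measured and on what is new or still open speak of the compounds shown alone.

Working notes on three measured compounds and one awaiting measurement. In a functional assay on MT4 cells (Homo sapiens) for cytotoxicity (on this read-out higher numbers stand for lower toxicity in this test and lower numbers for higher toxicity in this test), compound 1 `Cc1cn(C2CC(N=[N+]=[N-])C(COC(=O)OCCCCCCCCO)O2)c(=O)[nH]c1=O` gives > 50000 nM, which is a limit of this assay, not a number. Compound 2 `Cc1cn(C2CC(N=[N+]=[N-])C(COC(=O)NCCCO)O2)c(=O)[nH]c1=O` likewise gives only a limit in this assay, > 50000 nM. Compound 3 `Cc1cn(C2CC(N=[N+]=[N-])C(COC(=O)OCCCCCCO)O2)c(=O)[nH]c1=O` also gives a limit in this assay, > 50000 nM. Compound 2 therefore stands only at a limit, as do the other two values shown, all at the limit of > 50000 nM in this assay, at which 3 of the 3 values shown sit. The three computed steps are accordingly unreadable: a step that the two limits leave unreadable from compound 1 to compound 2, a step that the two limits leave unreadable from compound 1 to compound 3 and a step that the two limits leave unreadable from compound 2 to compound 3.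

Compound 4 `Cc1cn(C2CC(N=[N+]=[N-])C(COC(=O)OCCO)O2)c(=O)[nH]c1=O` differs from compound 2 by 2-hydroxyethoxy in place of (3-hydroxypropyl)amino on a carbonyl carbon. The nearest measured step, the change from compound 2 to compound 3, also exchanges a (3-hydroxypropyl)amino group on the carbonyl carbon for a hydroxyalkoxy group, and its size is not readable because both values sit at the limit of > 50000 nM in this assay, at which 3 of the 3 values shown sit. Among the measured compounds shown here, no measured step gives a direction, so no step beyond the scatter is expected, and the step that the limit leaves unreadable from compound 2 to compound 4 is expected to remain unreadable. Compound 4 is expected to give about 80000 nM in this assay, estimated between 30000 nM and 300000 nM, most likely reported again only as a limit.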

Compound 4, half-maximal cytotoxic concentration: > 50000 nM
Compound 4: a limit, no number (the forecaster's own chance of this, stated with the estimate: 85%); the middle value lies beyond the limit too.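

Compound 4 gives only a limit in this assay, like compound 1, compound 2 and compound 3, so none of the steps to compound 4 can be read: the limit of > 50000 nM in this assay, at which 4 of the 4 values shown sit.

The compounds shown leave open whether any of these side chains on the carbonyl carbon changes the read-out at all.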